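The source may report more compounds than this note shows. Statements on the series, on what has been measured and on what is new or still open speak of the compounds shown alone.

Compound 1 `Cc1ccc(C(=O)Nc2cccc(-c3oc4cc(-c5ccc(F)cc5)ccc4c(=O)c3O)c2)cc1` is the starting point here. Going by the values given here, in a functional assay on HepG2 cells (Homo sapiens) for antiproliferative activity, read by CCK-8 assay, with a stated time of 72 h (on this read-out lower numbers stand for stronger inhibition and higher numbers for weaker inhibition), compound 1 gives 2320 nM, the lowest of the two numbers measured so far. Among the compounds with values here, its only measured neighbour is compound 2 `N#Cc1ccc(C(=O)Nc2cccc(-c3oc4cc(-c5ccc(F)cc5)ccc4c(=O)c3O)c2)cc1`, which in this assay gives 7110 nM; that step, a 3.1-fold higher number from compound 1 to compound 2 (0.49 log units; beyond the scatter), shows that swapping the group at this position can move the number beyond the scatter.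

Compound 3 `O=C(Nc1cccc(-c2oc3cc(-c4ccc(F)cc4)ccc3c(=O)c2O)c1)c1ccc(-c2ccccc2)cc1` has not yet been measured. It differs from compound 1 in one place: phenyl in place of methyl on an aromatic carbon. Unlike the step to compound 2, this change brings in no nitrile; it simply enlarges the group at that position from methyl to phenyl.

Within the data shown here, the only measured step, from compound 1 to compound 2, concerns a different group, so it bears on compound 3 only loosely: it shows the site tolerates change with a modest penalty, nothing more. For compound 3 in this assay the step of a 1.4-fold higher number from compound 1 to compound 3 (0.14 log units; within the scatter) is therefore expected to be small, perhaps toward a slightly higher number. The value for compound 3 is estimated at 3200 nM, within a range from 1000 nM to 10000 nM.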

Compound 3, half-maximal inhibitory concentration: 88500 nM
Compound 3: middle estimate off by 28-fold (1.44 log units), on the low side, and the stated range ends below it.
By their numbers in this assay, from the lowest: compound 1; then compound 2; then compound 3.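

In this assay, the change from 4-methylphenyl to 4-phenylphenyl gives a 38-fold higher number from compound 1 to compound 3 (1.58 log units; beyond the scatter), and replacing the nitrile with phenyl gives a 12-fold higher number from compound 2 to compound 3 (1.10 log units; beyond the scatter). The earlier step, a 3.1-fold higher number from compound 1 to compound 2 (0.49 log units; beyond the scatter), suggested that this position responds only modestly to a change of group, but compound 3 shows that the group placed here can shift the number much further, and that the site does not accept every group with a modest penalty. Among these three compounds, the number rises from methyl to nitrile to phenyl, but nothing available explains why phenyl has such a large effect here.

These compounds leave open whether the large rise follows from the greater number of heavy atoms in phenyl or from the added aromatic ring, a question that groups such as ethyl, isopropyl or cyclohexyl at the same position could help to separate. They also leave open how an amine, a methoxy group or a carboxylic acid would behave there, and whether any group could bring the number below that of compound 1.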